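This account rests on a few compounds, and the source may have more. Where it says the series, first, only, none or still open, it means among the compounds named here.

Compound 1 `Cc1cc(/C=C/C#N)cc(C)c1Oc1cc(Nc2ccc(C#N)cc2)c(N)cc1C(N)=O`: > 23600 nM
Compound 2 `CNC(=O)c1cc(N)c(Nc2ccc(C#N)cc2)cc1Oc1c(C)cc(CCC#N)cc1C`: > 9100 nM

In an ADME assay on TZM cells (Homo sapiens) for cytotoxicity, read by XTT assay, with a stated time of 4 days (on this read-out higher numbers stand for lower toxicity in this test and lower numbers for higher toxicity in this test), compound 1 gives > 23600 nM, which is a limit and not an exact number. Compound 2 gives > 9100 nM, which is also a limit. Neither compound therefore has an exact value to place it on the scale.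

Compound 3 `Cc1cc(/C=C/C#N)cc(C)c1Oc1cc(Nc2ccc(C#N)cc2)c(N)cc1S(N)(=O)=O` has sulfamoyl in place of carbamoyl on an aromatic carbon of compound 1 (sulfamoyl in place of carbamoyl on an aromatic carbon). Within the data shown here, no measured pair shows the effect of this change. The expected step, an at least 1.1-fold lower number from compound 1 to compound 3 (0.07 log units; that floor lies within the scatter), is none beyond the usual scatter. For compound 3 the estimated value is 20000 nM, with an expected range from 6000 nM to 40000 nM.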

Compound 3, half-maximal cytotoxic concentration: > 21800 nM
Compound 3 ended at the assay's limit (the forecaster's own chance of this, stated with the estimate: 70%); middle value at least 1.0-fold (0.03 log units) away from the limit.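

Compound 1 gives > 23600 nM, which is a limit. Among these compounds, compound 3 gives > 21800 nM, also a limit, so no step between the two compounds can be read. On these data alone, what sulfamoyl in place of carbamoyl does in this assay stays open.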